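The source may report more compounds than this note shows. Statements on the series, on what has been measured and on what is new or still open speak of the compounds shown alone.

Of the compounds shown here, three that share one core have been measured in a functional assay on HEK293 cells for agonist activity at Bombesin receptor subtype-3 (Mus musculus), read by luminescence and calcium flux, with a stated time of 10 min; a lower number here means that less compound is needed, a higher number that more compound is needed for the effect. Compound 1 `CCC(C)(C)Cc1c[nH]c(CCc2ccc(-c3cccc(C#N)n3)cc2)n1` gives 26 nM; compound 2 `CCC(C)(C)Cc1c[nH]c(CCc2ccc(-c3cccc(N)n3)cc2)n1` gives 3.9 nM; compound 3 `CCC(C)(C)Cc1c[nH]c(CCc2ccc(-n3cncn3)cc2)n1` gives 12 nM, which places compound 3 second highest of the three, with compound 1 nearest and compound 2 furthest. The change from compound 3 to compound 4 `CCC(C)(C)Cc1c[nH]c(CCc2ccc(-c3ccns3)cc2)n1` is 1,2-thiazol-5-yl in place of 1H-1,2,4-triazol-1-yl on an aromatic carbon. Among the measured compounds shown here, no measured step swaps one five-membered ring for another; the steps that touch this position are a 2.2-fold lower number from compound 1 to compound 3 (0.34 log units; beyond the scatter) and a 3.1-fold higher number from compound 2 to compound 3 (0.49 log units; beyond the scatter), both modest. A modest step in this assay in either direction is therefore the most that is expected, and possibly none beyond the scatter. Compound 4 is estimated at 15 nM, between 5 nM and 50 nM, meaning a 1.3-fold higher number from compound 3 to compound 4 (0.10 log units; within the scatter).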

Compound 4, half-maximal effective concentration: 3.1 nM
Compound 4: middle estimate off by 4.8-fold (0.68 log units), on the high side, and the stated range ends above it.
By their numbers in this assay, from the lowest: compounds 4 and 2 (each within the scatter of the next); then compound 3; then compound 1.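

Exchanging one five-membered ring for another at this position can shift the result in this assay, as 1,2-thiazol-5-yl in place of 1H-1,2,4-triazol-1-yl gives a change beyond the scatter (a 3.9-fold lower number from compound 3 to compound 4 (0.59 log units; beyond the scatter)). A pyridine ring is also not needed here to reach the lowest level seen so far, as the 1,2-thiazol-5-yl group stays level with 6-aminopyridin-2-yl (a 1.3-fold lower number from compound 2 to compound 4 (0.10 log units; within the scatter)) and clearly improves on 6-cyanopyridin-2-yl (an 8.4-fold lower number from compound 1 to compound 4 (0.92 log units; beyond the scatter)). Nothing available explains the difference between the two five-membered rings. Since this swap changes the ring's sulfur and nitrogen content together, the contribution of each remains unseparated. On these data alone, how a carboxylic acid or a simple amine at this position would compare also remains open.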